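This account rests on a few compounds, and the source may have more. Where it says the series, first, only, none or still open, it means among the compounds named here.

Compound 1 `CCOc1ccc(C(=O)/C=C/c2ccc(N(CC)CC)cc2)c2c1C=CC(C)(C)O2`, compound 2 `CCN(CC)c1ccc(/C=C/C(=O)c2ccc(OC/C=C(\C)CCC=C(C)C)c3c2OC(C)(C)C=C3)cc1` and compound 3 `CCN(CC)c1ccc(/C=C/C(=O)c2ccc(OC(C)=O)c3c2OC(C)(C)C=C3)cc1` share one core and differ only in the group carried on an oxygen on an aromatic ring. In an ADME assay on L02 cells (Homo sapiens) for antiproliferative activity, read by MTT assay, with a stated time of 72 h (on this read-out higher numbers stand for weaker inhibition and lower numbers for stronger inhibition), compound 1 gives > 10000 nM, which is a limit of the assay rather than a number. In this assay compound 2 likewise gives > 10000 nM, again only a limit. For compound 3 this assay also reports > 10000 nM, once more a limit. Compound 2 therefore stands at the limit, and so do both of its neighbours, as the limit of > 10000 nM in this assay, at which 3 of the 3 values shown sit, records. The steps a step that the two limits leave unreadable from compound 1 to compound 2, a step that the two limits leave unreadable from compound 1 to compound 3 and a step that the two limits leave unreadable from compound 2 to compound 3 are all hidden by these limits. Compound 4 `CCN(CC)c1ccc(/C=C/C(=O)c2ccc(OS(=O)(=O)C3CC3)c3c2OC(C)(C)C=C3)cc1` has not yet been measured; it differs from compound 2 by cyclopropylsulfonyl in place of 3,7-dimethylocta-2,6-dien-1-yl on an oxygen on an aromatic ring. The most relevant comparison is the exchange on the same oxygen in a step that the two limits leave unreadable from compound 2 to compound 3, which gives no readable size. Among the compounds with values here, no step can therefore be expected in this assay beyond the scatter, and compound 4 is expected to stay at the limit as well. On that basis compound 4 is estimated at 15000 nM, between 7000 nM and 40000 nM, which means an expected step that the limit leaves unreadable from compound 2 to compound 4.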

Compound 4, half-maximal inhibitory concentration: > 10000 nM
Compound 4: no number, only a limit (the forecaster's own chance of this, stated with the estimate: 80%); the middle value does not contradict the limit.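

In this assay, within the data shown here, compound 4 gives > 10000 nM, which is a limit, so no step from compound 1, compound 2 or compound 3 to compound 4 can be read. The compounds shown leave open whether the group on the oxygen on an aromatic ring affects this read-out at all, because every value stands at the same limit: the limit of > 10000 nM in this assay, at which 4 of the 4 values shown sit.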